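Swapping the thiophene for a pyridine on a pyrimidinyl-piperazine pyridazine

The source may report more compounds than this note shows. Statements on the series, on what has been measured and on what is new or still open speak of the compounds shown alone.

Compound 1 `COc1cccc(-c2cc(C)c(N3CCN(c4ncccn4)CC3)nn2)c1`: 2600 nM
Compound 2 `Cc1ccc(-c2cc(C)c(N3CCN(c4ncccn4)CC3)nn2)cc1`: 17200 nM
Compound 3 `Cc1cc(-c2ccsc2)nnc1N1CCN(c2ncccn2)CC1`: 2400 nM

These three compounds share a core and differ only in the aromatic ring attached to it. In a functional assay on BV-2 cells (Mus musculus) for inhibition, read by ELISA, with a stated time of 16 h (on this read-out higher numbers stand for weaker inhibition and lower numbers for stronger inhibition), compound 3 gives the lowest number, although compound 1 sits within the scatter of it a 1.1-fold lower number from compound 1 to compound 3 (0.03 log units; within the scatter), while compound 2 is clearly weaker a 7.2-fold lower number from compound 2 to compound 3 (0.86 log units; beyond the scatter). Compound 4 `Cc1cc(-c2ccncc2)nnc1N1CCN(c2ncccn2)CC1` carries pyridin-4-yl in place of thiophen-3-yl on an aromatic carbon. Going by the values given here, no measured step swaps one six-membered ring for a five-membered one with a ring nitrogen, so the two ring swaps seen so far only show that this position tolerates some rings and not others. A modest weakening is therefore expected for compound 4, a 1.7-fold higher number from compound 3 to compound 4 (0.22 log units; within the scatter), giving an estimated value of 4000 nM with a range from 1500 nM to 12000 nM.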

Compound 4, half-maximal inhibitory concentration: > 100000 nM
Compound 4 was reported as a limit; the forecaster's own chance of this, stated with the estimate: 5%; at least 25-fold (1.39 log units) between middle value and limit.
By their numbers in this assay, from the lowest: compounds 3 and 1 (each within the scatter of the next); then compound 2. At a limit, above all of these: compound 4.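

Compound 4 is reported in this assay only as a limit: the limit of > 100000 nM in this assay, at which 1 of the 4 values shown sits. This position is far less forgiving than the earlier rings suggested, since pyridin-4-yl gives an at least 41-fold higher number from compound 3 to compound 4 (1.61 log units; beyond the scatter) and an at least 38-fold higher number from compound 1 to compound 4 (1.58 log units; beyond the scatter), and still an at least 5.8-fold higher number from compound 2 to compound 4 (0.76 log units; beyond the scatter). Among these compounds, then, replacing one aromatic ring with another can do far more than the earlier steps showed.

From the compounds shown here alone, whether the ring nitrogen of pyridin-4-yl is what matters stays open. So does how a plain phenyl ring, or a phenyl ring carrying an amine, would read here.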